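Shortening a side chain on a cysteinyl leukotriene receptor ligand

The source may hold more compounds than are shown below. What is called first, only, known or untested is meant among the compounds shown, and "the series" means these compounds.

The measured compounds and their values:

Compound 1, `CCCC(CCC(=O)O)Cc1ccc(OCc2ccc3ccccc3n2)cc1`, gives 21 nM.
Compound 2, `CC(CCC(=O)O)Cc1ccc(OCc2ccc3ccccc3n2)cc1`, gives 43 nM.
Compound 3, `CCCC(CCc1nnn[nH]1)Cc1cccc(OCc2ccc3ccccc3n2)c1`, gives 11 nM.

These three compounds were tested in an assay on membranes from lung (Cavia porcellus) for binding affinity to cysteinyl leukotriene receptor (Homo sapiens); on this read-out lower numbers stand for stronger inhibition and higher numbers for weaker inhibition. Compound 1 and compound 2 share one core and differ in a single place: hydrogen in place of ethyl on a saturated chain carbon, three bonds along the chain from an aromatic carbon. That change produced a 2.0-fold higher number from compound 1 to compound 2 (0.31 log units; beyond the scatter). Compound 3 carries a different core; the difference between the two cores is not broken down here. Its value in this assay is the lowest of the three numbers, but its gap to compound 1 lies within the scatter, so no order between compound 3 and compound 1 can be claimed. Compound 3 does stand beyond the scatter from compound 2.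

Compound 4, `CC(CCc1nnn[nH]1)Cc1cccc(OCc2ccc3ccccc3n2)c1`, has not yet been measured in this assay. It differs from compound 3 in one place: hydrogen in place of ethyl on a saturated chain carbon, three bonds along the chain from an aromatic carbon. Among the measured compounds shown here, this is the same change as the one made from compound 1 to compound 2, and both changes sit at the same place on the saturated chain. Because the earlier change gave a 2.0-fold higher number from compound 1 to compound 2 (0.31 log units; beyond the scatter), a step of similar size is expected here, namely a 2.0-fold higher number from compound 3 to compound 4 (0.30 log units; within the scatter). On this basis compound 4 is estimated at 22 nM in this assay, with a likely range from 10 nM to 50 nM. The estimate rests on a single earlier pair, and the two cores differ, so the range is kept broad.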

Compound 4, inhibition constant: 34 nM
Compound 4: middle estimate off by 1.5-fold (0.19 log units), on the low side; low and high end bracket the measured number.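

In this assay, putting hydrogen in place of ethyl on a saturated chain carbon, three bonds along the chain from an aromatic carbon, gave a 3.1-fold higher number from compound 3 to compound 4 (0.49 log units; beyond the scatter), so the change that weakened inhibition on the core of compound 1 also weakened it on the core of compound 3. The two steps cannot be told apart in size, which means that in these two pairs the change carried over from one core to the other in both direction and approximate size: the same change on two cores in this assay, a 2.0-fold higher number (0.31 log units; beyond the scatter) from compound 1 to compound 2 and a 3.1-fold higher number (0.49 log units; beyond the scatter) from compound 3 to compound 4, 1.5-fold (0.18 log units) apart, within the scatter of two such steps

Among the compounds shown here, this is still only two pairs in a single assay, so it does not show that the change would behave the same way on any further core, and it does not explain why the change raises the number on either core.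

As far as these compounds go, what a chain longer than propyl, or a hydroxyl group or an amine on the same chain carbon, would do to the number remains open. From the compounds shown here alone, it is also open whether the step would hold on a third core, for example one carrying a sulfonamide.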